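The source may hold more compounds than are shown below. What is called first, only, known or untested is meant among the compounds shown, and "the series" means these compounds.

Measured in an ADME assay on MT4 cells (Homo sapiens) for cytotoxicity, read by MTT assay, with a stated time of 5 days; on this read-out higher numbers stand for lower toxicity in this test and lower numbers for higher toxicity in this test:
- compound 1 `COc1cc2nc(Nc3ccc(C#N)cc3)nc(Nc3c(Cl)cc(/C=C/C#N)cc3Cl)c2cc1OC` gives 9920 nM
- compound 2 `COc1cc2nc(SCC(=O)Nc3cccc(Cl)c3)nc(Nc3c(Cl)cc(/C=C/C#N)cc3Cl)c2cc1OC` gives > 208000 nM, which is a limit of the assay and not a number

Compound 2 stands at the limit of > 208000 nM in this assay, at which 1 of the 2 values shown sits. Compound 3 `COc1cc2nc(SCC(=O)Nc3ccc(Cl)cc3)nc(Nc3c(Cl)cc(/C=C/C#N)cc3Cl)c2cc1OC` has 4-chlorophenyl in place of 3-chlorophenyl on an amide-type nitrogen. Among the compounds with values here, the only measured step, an at least 20-fold higher number from compound 1 to compound 2 (1.32 log units; beyond the scatter), was large, but it exchanged the whole (4-cyanophenyl)amino group, a much bigger change than this one. The expected step in this assay is therefore none beyond the scatter: an at least 1.1-fold lower number from compound 2 to compound 3 (0.06 log units; that floor lies within the scatter). The estimate for compound 3 is 180000 nM, with an expected range of 50000 nM to 208000 nM.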

Compound 3, half-maximal cytotoxic concentration: 29500 nM
Estimate against measurement, compound 3: 6.1-fold (0.79 log units) above; the whole stated range lies above it.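

In this assay, moving the chlorine alone, with 4-chlorophenyl in place of 3-chlorophenyl on the amide-type nitrogen, gives an at least 7.0-fold lower number from compound 2 to compound 3 (0.84 log units; beyond the scatter), so this small change of the same atoms clearly raises toxicity in this test. The sulfanyl side chain therefore does not carry the low toxicity by itself: with the 4-chlorophenyl end it gives a 3.0-fold higher number from compound 1 to compound 3 (0.47 log units; beyond the scatter). Compound 2 has a limit and not a number, so the first step is only a floor: the limit of > 208000 nM in this assay, at which 1 of the 3 values shown sits.

On these data alone, whether a plain phenyl or a 4-methoxyphenyl on the same nitrogen would sit nearer compound 2 or compound 3 stays open.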